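The source may hold more compounds than are shown below. What is called first, only, known or untested is meant among the compounds shown, and "the series" means these compounds.

In an ADME assay on HEK-293T cells (Homo sapiens) for cytotoxicity, read by MTT assay, with a stated time of 3 days (a higher number here means that more compound is tolerated, a lower number that less compound is tolerated), compound 1 `CC(C)(C)N(CCCc1ccccc1)C(=O)COC(=O)c1ccc([N+](=O)[O-])o1` is reported as "not active" (no number reported), without a number. Compound 2 `CC(C)(C)N(Cc1ccc([N+](=O)[O-])cc1)C(=O)COC(=O)c1ccc([N+](=O)[O-])o1` gives > 100000 nM, which is a limit of the assay. From the compounds shown here alone, compound 3 `CC(C)(C)N(Cc1ccc(F)cc1)C(=O)COC(=O)c1ccc([N+](=O)[O-])o1` gives > 100000 nM, likewise a limit and not a number, so its exact standing is unknown. In compound 4 `CC(C)(C)N(Cc1cccc(C(F)(F)F)c1)C(=O)COC(=O)c1ccc([N+](=O)[O-])o1`, 3-(trifluoromethyl)phenyl replaces 4-fluorophenyl (3-(trifluoromethyl)phenyl in place of 4-fluorophenyl on a saturated chain carbon bound to an amide-type nitrogen). For the measured compounds named here, the one measured step that bears on this, a step that the two limits leave unreadable from compound 2 to compound 3, has no readable size, and its two ends sit at the limit of > 100000 nM in this assay, at which 2 of the 3 values shown sit. That gives no ground for expecting a change beyond the usual scatter in this assay, in either direction. The expected step is a step that the limit leaves unreadable from compound 3 to compound 4. Compound 4 is expected near 120000 nM, within an estimated range from 40000 nM to 300000 nM.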

Compound 4, half-maximal cytotoxic concentration: 68000 nM
Estimate against measurement, compound 4: 1.8-fold (0.25 log units) above; low and high end bracket the measured number.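

At this position, on a saturated chain carbon bound to an amide-type nitrogen, compound 4 with 3-(trifluoromethyl)phenyl gives 68000 nM in this assay and is the only compound shown with a number rather than a limit or no value. This gives an at least 1.4-fold lower number from compound 3 to compound 4 (0.16 log units; that floor lies within the scatter) and an at least 1.4-fold lower number from compound 2 to compound 4 (0.16 log units; that floor lies within the scatter) as the two partly readable steps. Each is only a floor and establishes no real change, because the other end of each step is a limit: the limit of > 100000 nM in this assay, at which 2 of the 4 values shown sit.

From the compounds shown here alone, how far compound 2 and compound 3 truly lie from compound 4 stays open. So does what a phenyl ring carrying an amine or a carboxylic acid would give here.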